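Serum stability: lengthening the nitrooxy arm of compound 1

The compounds below may be only part of what the source reports. "The series", "measured", "known", "first", "only" and "open" are said of these compounds alone.

Within the data shown here, compound 1 `Cc1c(C)c2ccc(OCC3CCN(Cc4cccc(CO[N+](=O)[O-])c4)CC3)cc2oc1=O` gives 36.8 h in an ADME assay on a cell-free system (serum, Homo sapiens) for metabolic stability, read by HPLC, tested at 100 uM (on this read-out higher numbers stand for a longer-lived compound and lower numbers for a shorter-lived compound), and stands at the top of the two numbers so far; its only neighbour, compound 2 `Cc1c(C)c2ccc(OCC3CCN(CCCO[N+](=O)[O-])CC3)cc2oc1=O`, gives 23 h in this assay, and a 1.6-fold lower number from compound 1 to compound 2 (0.20 log units; within the scatter) is within the scatter. Compound 3 `Cc1c(C)c2ccc(OCC3CCN(Cc4cccc(OCCCO[N+](=O)[O-])c4)CC3)cc2oc1=O` differs from compound 1 by 3-(nitrooxy)propoxy in place of (nitrooxy)methyl on an aromatic carbon. Among the measured compounds shown here, the single measured step, a 1.6-fold lower number from compound 1 to compound 2 (0.20 log units; within the scatter), exchanged the whole group on the ring amine and moved the number little; no measured step alters a group on the aromatic ring itself. The step of a 1.2-fold lower number from compound 1 to compound 3 (0.09 log units; within the scatter) is therefore expected to stay within the scatter in this assay. Compound 3 is estimated at 30 h, within 15 h to 60 h.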

Compound 3, half-life: 458 h
Compound 3: middle estimate off by 15-fold (1.18 log units), on the low side; measured number above the stated range.
By their numbers in this assay, from the lowest: compounds 2 and 1 (each within the scatter of the next); then compound 3.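

On the aromatic carbon, 3-(nitrooxy)propoxy in place of (nitrooxy)methyl gives a 12-fold higher number from compound 1 to compound 3 (1.10 log units; beyond the scatter) in this assay and so shows that this position can carry a large step, which the exchange on the ring amine, a 1.6-fold lower number from compound 1 to compound 2 (0.20 log units; within the scatter), did not show. The entering group differs from the leaving one in both chain and ring-bound oxygen, and this single step cannot separate the two. Nothing available accounts for the rise.

Open, on these data alone, is whether a shorter or longer chain ending in the same nitrooxy group holds this number. Also open, as far as these compounds go, is whether a propyl chain without the ether oxygen does the same.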